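Swapping the alkene substituent for phenyl in compound 4

The source may report more compounds than this note shows. Statements on the series, on what has been measured and on what is new or still open speak of the compounds shown alone.

Measured compounds:
- compound 1, `O=C(/C(=C/c1ccccc1)CCl)c1ccccc1`: 18000 nM
- compound 2, `CC(=O)OC/C(=C\C1CCCCC1)C(=O)c1ccccc1`: 22000 nM
- compound 3, `CCC(/C=C(\COC(C)=O)C(=O)c1ccccc1)CC`: 89000 nM

These three compounds were tested in a functional assay on T47D cells (Homo sapiens) for inhibition, read by sulforhodamine B assay, with a stated time of 48 h; on this read-out higher numbers stand for weaker inhibition of growth and lower numbers for stronger inhibition of growth. Compound 3 gives the highest number of the three, so it is the weakest inhibitor of growth in this set; its nearest neighbour is compound 2, and compound 1 lies furthest below it.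

Compound 4, `CC(=O)OC/C(=C\c1ccccc1)C(=O)c1ccccc1`, has not yet been measured. It differs from compound 3 in one place: phenyl in place of pentan-3-yl on a double-bonded chain carbon bound to a double-bonded chain carbon. Going by the values given here, the only measured step that touches this position is the one from compound 2 to compound 3, where pentan-3-yl replaced cyclohexyl and gave a 4.0-fold higher number from compound 2 to compound 3 (0.61 log units; beyond the scatter). Compound 4 reverses the direction of that change, putting a six-membered aromatic ring of carbon only where compound 3 carries a branched chain. Compound 1 also carries phenyl at this position, though on a core with a chloromethyl rather than an acetoxymethyl group, and it gives a number close to that of compound 2. The return to a ring group is therefore expected to lower the number, by a step of about a 4.5-fold lower number from compound 3 to compound 4 (0.65 log units; beyond the scatter). Compound 4 is estimated to give 20000 nM, with a range from 7000 nM to 60000 nM.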

Compound 4, concentration for 50% growth inhibition: 16000 nM
For compound 4 the middle estimate is 1.3-fold (0.10 log units) above the measured one; low and high end bracket the measured number.
By their numbers in this assay, from the lowest: compounds 4, 1 and 2 (each within the scatter of the next); then compound 3.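

Seen in this assay, the phenyl in place of pentan-3-yl on a double-bonded chain carbon bound to a double-bonded chain carbon gives a 5.6-fold lower number from compound 3 to compound 4 (0.75 log units; beyond the scatter), showing that an aromatic ring at this position also separates from the branched chain, which the earlier step showed only for cyclohexyl. Phenyl in place of cyclohexyl gives a 1.4-fold lower number from compound 2 to compound 4 (0.14 log units; within the scatter), so in these compounds the aromatic and the saturated ring cannot be told apart, and pentan-3-yl, the only group here without a ring, stands alone with the highest number. Acetoxy in place of chloro on a saturated chain carbon bound to a double-bonded chain carbon gives a 1.1-fold lower number from compound 1 to compound 4 (0.05 log units; within the scatter), so with phenyl held in place, this exchange produces no change that can be read above the usual scatter.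

Nothing given here explains these differences in growth inhibition. Still open, from the compounds shown here alone, is whether the link between a ring and the lower numbers holds beyond these compounds, for instance with a straight hexyl chain in place of pentan-3-yl, or with an amine or a carboxylic acid carried on the phenyl ring.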